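Nitro for trifluoromethyl at the edge of a limit

The source may hold more compounds than are shown below. What is called first, only, known or untested is meant among the compounds shown, and "the series" means these compounds.

In a functional assay on CEM-SS cells (Homo sapiens) for cytotoxicity (on this read-out higher numbers stand for weaker inhibition and lower numbers for stronger inhibition), compound 3 (`FC(F)(F)c1cccc(Cn2c(Cl)nc3cc(Cl)c(Cl)cc32)c1`) gives > 100000 nM, which is a limit and not a number. Compound 2 (`Cc1cccc(Cn2c(Cl)nc3cc(Cl)c(Cl)cc32)c1`) gives > 100000 nM, also a limit. Together they sit at the limit of > 100000 nM in this assay, at which 2 of the 3 values shown sit. For the measured compounds named here, the only measured step nearby is a step that the two limits leave unreadable from compound 2 to compound 3, so it gives no size to carry forward.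

Compound 4 (`O=[N+]([O-])c1cccc(Cn2c(Cl)nc3cc(Cl)c(Cl)cc32)c1`) has nitro in place of trifluoromethyl on an aromatic carbon, meta to a large group: nitro in place of trifluoromethyl on an aromatic carbon. Going by the values given here, the one hint comes from compound 1 (`Nc1nc2cc(Cl)c(Cl)cc2n1Cc1cccc([N+](=O)[O-])c1`), which also carries nitro and gives a true number, 47000 nM, in this assay. Since the steps give no size, only a small move toward stronger inhibition in this assay is expected, and compound 4 may well stay at the limit. The expected change is an at least 1.1-fold lower number from compound 3 to compound 4 (0.04 log units; that floor lies within the scatter). For compound 4 the estimated value is 90000 nM, with an expected range from 35000 nM to 150000 nM.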

Compound 4, half-maximal inhibitory concentration: > 100000 nM
Compound 4 ended at the assay's limit; the forecaster's own chance of this, stated with the estimate: 60%; at least 1.1-fold (0.04 log units) between middle value and limit.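

Nitro on this aromatic carbon does not by itself give a true number in this assay, so the measured value of compound 1 cannot rest on its nitro alone. For the compounds shown here, with nitro kept, the one readable step is chloro in place of amino on an aromatic carbon, and it points to that other position as the place that matters here: an at least 2.1-fold higher number from compound 1 to compound 4 (0.32 log units; beyond the scatter). The steps among compound 2, compound 3 and compound 4 cannot be read, as all three values are limits, and most of the set now sits at one ceiling: the limit of > 100000 nM in this assay, at which 3 of the 4 values shown sit.

On these data alone, what true numbers lie behind those three limits stays open. So does whether amino in place of chloro would also give a number alongside methyl or trifluoromethyl, and what a carboxylic acid on this aromatic carbon would give.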